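The compounds below may be only part of what the source reports. "The series", "measured", "known", "first", "only" and "open" are said of these compounds alone.

Measured in an ADME assay on MT4 cells (Homo sapiens) for cytotoxicity, read by MTT assay, with a stated time of 4 days; a lower number here means that less compound is tolerated, a higher number that more compound is tolerated:
Compound 1 `O=C(COc1cccc2ccccc12)N/N=C/c1ccccc1Br`: 11.4 ug/mL
Compound 2 `O=C(COc1cccc2ccccc12)N/N=C/c1ccc(Br)cc1`: 106 ug/mL
Compound 3 `O=C(COc1cccc2ccccc12)N/N=C/c1ccc([N+](=O)[O-])cc1`: 87.9 ug/mL

On these numbers, compound 3 stands level with compound 2 within the scatter, and compound 1 has the lowest value. Compound 4 `O=C(COc1cccc2ccccc12)N/N=C/c1ccccc1` has hydrogen in place of nitro on an aromatic carbon, para to a large group (hydrogen in place of nitro on an aromatic carbon). The closest guide is nitro in place of bromo, which gave a 1.2-fold lower number from compound 2 to compound 3 (0.08 log units; within the scatter). The larger 9.3-fold higher number from compound 1 to compound 2 (0.97 log units; beyond the scatter) concerns 2-bromophenyl, a group that compound 3 and compound 4 both lack. Among the compounds with values here, no measured compound has hydrogen at this place, so the guide is thin. The expected step is none beyond the scatter, and the estimate is a 1.1-fold lower number from compound 3 to compound 4 (0.04 log units; within the scatter). The estimated value for compound 4 is 80 ug/mL, with a range from 30 ug/mL to 180 ug/mL.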

Compound 4, half-maximal cytotoxic concentration: >= 96.6 ug/mL
Compound 4 ended at the assay's limit; the forecaster's own chance of this, stated with the estimate: 15%; middle value at least 1.2-fold (0.08 log units) away from the limit.
By their numbers in this assay, from the lowest: compound 1; then compounds 3 and 2 (each within the scatter of the next).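

In this assay compound 4 gives >= 96.6 ug/mL, which is a limit of the assay and not a number: the limit of >= 96.6 ug/mL in this assay, at which 1 of the 4 values shown sits. Hydrogen in place of nitro gives an at least 1.0-fold higher number from compound 3 to compound 4 (0.04 log units; that floor lies within the scatter), and hydrogen in place of bromo gives an at least 8.4-fold higher number from compound 1 to compound 4 (0.92 log units; beyond the scatter), so the ring needs no group at this place to keep a high number. The step from the 4-bromophenyl compound cannot be read.

From the compounds shown here alone, how an amine or a carboxylic acid at this place would read remains open. So does how far the true number lies past the limit.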